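The source may hold more compounds than are shown below. What is called first, only, known or untested is meant among the compounds shown, and "the series" means these compounds.

Measured compounds:
compound 1, `CO[C@H]1C[C@H](C)CC2=C(N3CCC3)C(=O)C=C(NC(=O)/C(C)=C/C=C\[C@H](OC)[C@@H](OC(N)=O)/C(C)=C/[C@H](C)/C1=N\O)C2=O`, 310 nM
compound 2, `CO[C@H]1C[C@H](C)CC2=C(NCCN(C)C)C(=O)C=C(NC(=O)/C(C)=C/C=C\[C@H](OC)[C@@H](OC(N)=O)/C(C)=C/[C@H](C)C1=O)C2=O`, 100 nM
compound 3, `CO[C@H]1C[C@H](C)CC2=C(NCCN(C)C)C(=O)C=C(NC(=O)/C(C)=C/C=C\[C@H](OC)[C@@H](OC(N)=O)/C(C)=C/[C@H](C)/C1=N\O)C2=O`, 95 nM

All three were tested in a functional assay on SK-BR-3 cells (Homo sapiens) for cytotoxicity, read by CellTiter-Glo, with a stated time of 72 h; on this read-out lower numbers stand for stronger inhibition and higher numbers for weaker inhibition. Compound 2 and compound 3 share one substituent on the core, but their cores differ; that difference between the two cores is not broken down here. What the values show is that compound 2 and compound 3 lie within the scatter of each other.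

Compound 1 is made from compound 3 by one change, (azetidin-1-yl in place of (2-(dimethylamino)ethyl)amino on a double-bonded ring carbon). That step in this assay was a 3.3-fold higher number from compound 3 to compound 1 (0.51 log units; beyond the scatter).

The unmeasured compound 4, `CO[C@H]1C[C@H](C)CC2=C(N3CCC3)C(=O)C=C(NC(=O)/C(C)=C/C=C\[C@H](OC)[C@@H](OC(N)=O)/C(C)=C/[C@H](C)C1=O)C2=O`, carries the same change on the core of compound 2: azetidin-1-yl in place of (2-(dimethylamino)ethyl)amino on a double-bonded ring carbon. Because this is the same change that gave a 3.3-fold higher number from compound 3 to compound 1 (0.51 log units; beyond the scatter), a step of about the same size is expected from compound 2 to compound 4, namely a 3.1-fold higher number from compound 2 to compound 4 (0.49 log units; beyond the scatter). This expectation rests on a single prior example, so the range is kept wide. For compound 4 the estimated value in this assay is 310 nM, with a likely spread from 150 nM to 650 nM.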

Compound 4, half-maximal inhibitory concentration: 260 nM
Compound 4: middle estimate off by 1.2-fold (0.08 log units), on the high side, within the range that was stated.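

In this assay, putting azetidin-1-yl in place of (2-(dimethylamino)ethyl)amino on the second core gave a 2.6-fold higher number from compound 2 to compound 4 (0.41 log units; beyond the scatter). The change therefore moved the number in the same direction on both cores, and the two steps do not differ by more than the usual scatter: the same change on two cores in this assay, a 3.3-fold higher number (0.51 log units; beyond the scatter) from compound 3 to compound 1 and a 2.6-fold higher number (0.41 log units; beyond the scatter) from compound 2 to compound 4, 1.3-fold (0.10 log units) apart, within the scatter of two such steps This shows that, for these two closely related cores, the size of the step measured on one core was a fair guide to the step on the other, but two pairs do not show that it would hold on any further core, and they do not tell which difference between the two groups lies behind the step.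

The compounds shown leave open how other groups on the same double-bonded ring carbon would behave, such as a pyrrolidine ring, a morpholine ring or a plain methylamino group. They also leave open what a longer chain ending in the same dimethylamino group, or a chain ending in a carboxylic acid, would give.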